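The compounds below may be only part of what the source reports. "The series", "measured", "known", "first", "only" and "open" are said of these compounds alone.

Compound 2 `Cc1ccc2ncc(S(=O)(=O)c3ccc(Cl)c(Cl)c3)c(N3CCC(C)CC3)c2c1` holds the highest of the two numbers in an assay on isolated protein for displacement of a labelled ligand from metabotropic glutamate receptor 5 (Homo sapiens), with a stated time of 60 min, tested at 1 uM (a higher number here means more inhibition at the concentration tested (going by the name of the read-out), a lower number less inhibition), where compound 2 gives 82%; its nearest neighbour is compound 1 `COc1ccc(S(=O)(=O)c2cnc3ccc(C)cc3c2N2CCC(C)CC2)cc1`, and in this assay compound 1 gives 62%. Going by the values given here, the only measured step on the aryl group at the sulfonyl sulfur, a number 20 percentage points higher from compound 1 to compound 2 (beyond the scatter), shows that changing that group moves this assay modestly. Compound 3 `Cc1cc(C)cc(S(=O)(=O)c2cnc3ccc(C)cc3c2N2CCC(C)CC2)c1` differs from compound 2 by 3,5-dimethylphenyl in place of 3,4-dichlorophenyl on a sulfonyl sulfur. Among the compounds with values here, no measured step shows this exact exchange, so compound 3 is expected at 70%, within 50% to 88%, the estimated step of a number 12 percentage points lower from compound 2 to compound 3 (beyond the scatter) being modest and downward.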

Compound 3, a percentage reported as inhibition, at one concentration (the size of the read-out at that concentration, not a potency): 80%
Compound 3: the middle estimate sits 10 percentage points below what was measured; the measured number falls inside the stated range.
By their numbers in this assay, from the lowest: compound 1; then compounds 3 and 2 (each within the scatter of the next).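

At the aryl group on the sulfonyl sulfur, this assay does not separate 3,5-dimethylphenyl from 3,4-dichlorophenyl, with a number 2 percentage points lower from compound 2 to compound 3 (within the scatter). Replacing 4-methoxyphenyl with 3,5-dimethylphenyl gives a number 18 percentage points higher from compound 1 to compound 3 (beyond the scatter), so a group with carbon alone matches the earlier gain seen with the dichlorophenyl group. No evidence at hand bears on why these two groups read alike.

Still open, going by these compounds, is how a carboxylic acid or an amine on this aryl group would read in this assay, and whether a single methyl or a single chlorine would be enough.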